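Adding a third methoxy to the aryl on compound 2

A few compounds are considered here, and "the series" means these few. Any claim that something is new, unique, unknown or untested is made for them only; others in the source may bear on it.

Two pyrazoline sulfonamides with a shared core have been tested in a functional assay on Malme-3M cells (Homo sapiens) for antiproliferative activity, with a stated time of 48 h; on this read-out lower numbers stand for stronger inhibition of growth and higher numbers for weaker inhibition of growth. Compound 1 `Cc1cc(O)c(C2=NN(c3ccc(S(N)(=O)=O)cc3)C(c3ccccc3Cl)C2)cc1Cl` gives 6460 nM. Compound 2 `COc1ccc(C2CC(c3cc(Cl)c(C)cc3O)=NN2c2ccc(S(N)(=O)=O)cc2)cc1OC` gives 24600 nM, which is the higher of the two numbers, so compound 2 inhibits growth more weakly. Within the data shown here, the only step measured so far, a 3.8-fold higher number from compound 1 to compound 2 (0.58 log units; beyond the scatter), exchanges the whole aryl group on the saturated ring carbon.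

Compound 3 `COc1ccc(C2CC(c3cc(Cl)c(C)cc3O)=NN2c2ccc(S(N)(=O)=O)cc2)c(OC)c1OC` differs from compound 2 by a smaller change: methoxy in place of hydrogen on an aromatic carbon, so the 3,4-dimethoxyphenyl becomes a 2,3,4-trimethoxyphenyl. Among the measured compounds shown here, no measured pair shows what one added methoxy does on this aryl; the step from compound 1 to compound 2 only shows that this part of the molecule can move the number beyond the scatter when the aryl is swapped wholesale. With nothing more specific to rest on, the expected step of a 1.0-fold higher number from compound 2 to compound 3 (0.01 log units; within the scatter) is small and may stay within the scatter. For compound 3 the expected value in this assay is 25000 nM, with a range from 9000 nM to 70000 nM.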

Compound 3, concentration for total growth inhibition: 4890 nM
Compound 3: the middle estimate sits 5.1-fold (0.71 log units) above what was measured; the measured number lies below the stated range.
By their numbers in this assay, from the lowest: compounds 3 and 1 (each within the scatter of the next); then compound 2.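

In this assay, putting a methoxy in place of hydrogen on an aromatic carbon, ortho to a large group and ortho to a methoxy group, gives a 5.0-fold lower number from compound 2 to compound 3 (0.70 log units; beyond the scatter) and so moves the number beyond the scatter. Until now, only the wholesale swap of one aryl for another had shown that this part of the molecule matters, with a 3.8-fold higher number from compound 1 to compound 2 (0.58 log units; beyond the scatter) going upward; here a single added group on the 3,4-dimethoxyphenyl goes the opposite way, and the result shows that the pattern of groups on this aryl counts, not just the kind of aryl present. The 2,3,4-trimethoxyphenyl also brings the number back level with the 2-chlorophenyl, as a 1.3-fold lower number from compound 1 to compound 3 (0.12 log units; within the scatter) stays within the scatter and leaves those two compounds indistinguishable here.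

Nothing available here explains why the added methoxy acts this way. On these data alone, whether the gain is tied to methoxy itself also stays open, and a hydroxyl, a fluorine or an ethoxy on the same aromatic carbon would show whether other groups there do the same.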